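Replacing 2-fluoro-5-iodophenyl with 6-methoxypyridin-3-yl

The source may report more compounds than this note shows. Statements on the series, on what has been measured and on what is new or still open speak of the compounds shown alone.

In a functional assay on K562 cells (Homo sapiens) for antiproliferative activity, read by MTT assay, with a stated time of 24 h (a lower number here means a stronger inhibitor, a higher number a weaker inhibitor), compound 1 (`COC(=O)c1scc(-c2ccc(NC(=O)c3ccc4ccccc4c3)cc2)c1OC`), which carries naphthalen-2-yl on a carbonyl carbon, gives 10300 nM as its half-maximal inhibitory concentration. Compound 2 (`COC(=O)c1scc(-c2ccc(NC(=O)c3cc(I)ccc3F)cc2)c1OC`) gives 35600 nM and so holds the higher of the two numbers, making it the weaker inhibitor of the pair. Compound 3 (`COC(=O)c1scc(-c2ccc(NC(=O)c3ccc(OC)nc3)cc2)c1OC`) keeps the shared core and differs from compound 2 in one place, with 6-methoxypyridin-3-yl in place of 2-fluoro-5-iodophenyl on a carbonyl carbon and nothing else altered. Among the measured compounds shown here, only one measured step bears on this change, since it involves the same carbonyl carbon and the same 2-fluoro-5-iodophenyl group. That step is a 3.5-fold higher number from compound 1 to compound 2 (0.54 log units; beyond the scatter) and counts as modest. For the measured compounds named here, no measured compound carries 6-methoxypyridin-3-yl, so the direction rests only on compound 2 lying at the high end of the two numbers, with 35600 nM as its value. In this assay the expected change is a 2.0-fold lower number from compound 2 to compound 3 (0.30 log units; within the scatter) and is estimated to be smaller than the measured step. For compound 3 the estimate is 18000 nM with an expected range from 6000 nM to 55000 nM in this read-out.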

Compound 3, half-maximal inhibitory concentration: 18300 nM
Compound 3: the middle estimate sits 1.0-fold (0.01 log units) below what was measured, within the range that was stated.
By their numbers in this assay, from the lowest: compounds 1, 3 and 2 (each within the scatter of the next, the first and the last beyond it).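

Swapping 2-fluoro-5-iodophenyl for 6-methoxypyridin-3-yl on a carbonyl carbon, an exchange of equal heavy-atom count that brings in a ring hetero atom and hydrogen-bond acceptors, gives in this assay a 1.9-fold lower number from compound 2 to compound 3 (0.29 log units; within the scatter) and so does not separate the two compounds. Set against naphthalen-2-yl, the same group gives a 1.8-fold higher number from compound 1 to compound 3 (0.25 log units; within the scatter) and again stays inside the scatter, so compound 3 cannot be told apart from either neighbour even though compound 1 and compound 2 are themselves separated beyond it; at this position in this assay, a pyridine ring bearing a methoxy group is thus tolerated without any readable change from either carbon-only aromatic group. No measured evidence is available that accounts for these numbers.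

The compounds shown do not separate the contribution of the ring nitrogen from that of the methoxy group, since both enter together in compound 3, and an unsubstituted pyridin-3-yl or a 4-methoxyphenyl group would be needed to pull them apart. They also leave open what happens on this carbonyl carbon without an aromatic ring at all, as with a piperidine ring, an amine-bearing chain or a carboxylic acid.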